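Swapping Propyl for Phenyl on the Amide of Compound 3

The source may report more compounds than this note shows. Statements on the series, on what has been measured and on what is new or still open speak of the compounds shown alone.

Measured so far in an assay on isolated protein for displacement of a labelled ligand from Type-2 angiotensin II receptor (Homo sapiens), with a stated time of 180 min; a lower number here means a stronger inhibitor, a higher number a weaker inhibitor:
Compound 1 `CCCCNC(=O)c1cc(C)c2nc(CCC)n(Cc3ccc(-c4ccccc4C(=O)O)cc3)c2c1` gives 164 nM.
Compound 2 `CCCc1nc2c(C)cc(NC(=O)CC)cc2n1Cc1ccc(-c2ccccc2C(=O)O)cc1` gives 78 nM.
Compound 3 `CCCC(=O)Nc1cc(C)c2nc(CCC)n(Cc3ccc(-c4ccccc4C(=O)O)cc3)c2c1` gives 53 nM.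

Compound 3 has the lowest number of the three, yet its gap to compound 2, a 1.5-fold lower number from compound 2 to compound 3 (0.17 log units; within the scatter), lies within the scatter, while a 3.1-fold lower number from compound 1 to compound 3 (0.49 log units; beyond the scatter) lies beyond it. The unmeasured compound 4 `CCCc1nc2c(C)cc(NC(=O)c3ccccc3)cc2n1Cc1ccc(-c2ccccc2C(=O)O)cc1` differs from compound 3 by phenyl in place of propyl on a carbonyl carbon. Within the data shown here, no measured step alters this same part: a 2.1-fold lower number from compound 1 to compound 2 (0.32 log units; beyond the scatter) and a 3.1-fold lower number from compound 1 to compound 3 (0.49 log units; beyond the scatter) reverse the amide, and only a 1.5-fold lower number from compound 2 to compound 3 (0.17 log units; within the scatter) touches the chain, placing methyl in place of hydrogen without a shift beyond the scatter. A larger replacement at that spot is therefore expected to move this assay only a little, in either direction, so a 1.1-fold higher number from compound 3 to compound 4 (0.05 log units; within the scatter) is the estimated step. Compound 4 is expected to give 60 nM, between 25 nM and 150 nM.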

Compound 4, half-maximal inhibitory concentration: 6 nM
Compound 4: the middle estimate sits 10-fold (1.00 log units) above what was measured; the whole stated range lies above it.
By their numbers in this assay, from the lowest: compound 4; then compounds 3 and 2 (each within the scatter of the next); then compound 1.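

In this assay the group on the carbonyl carbon matters far more than the earlier chains suggested: phenyl in place of propyl gives the step (an 8.8-fold lower number from compound 3 to compound 4 (0.95 log units; beyond the scatter)), and phenyl in place of ethyl gives (a 13-fold lower number from compound 2 to compound 4 (1.11 log units; beyond the scatter)), although propyl and ethyl themselves stay within the scatter of each other. Benzamido in place of butylcarbamoyl gives the widest step (a 27-fold lower number from compound 1 to compound 4 (1.44 log units; beyond the scatter)). Nothing available explains this gain.

On these data alone, whether it requires an aromatic ring or only a larger group remains open. Cyclohexyl, pyridyl or methoxyphenyl on the same carbonyl carbon would help separate these possibilities.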